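The compounds below may be only part of what the source reports. "The series", "measured", "known", "first", "only" and "open" are said of these compounds alone.

Of the compounds shown here, three have so far been tested in a functional assay on UACC-257 cells (Homo sapiens) for cytotoxicity, read by sulforhodamine B assay, with a stated time of 48 h; on this read-out higher numbers stand for weaker inhibition of growth and lower numbers for stronger inhibition of growth. Compound 1 `ClCc1ccc(Cn2cnc3c(Cl)ncnc32)cc1` gives 28800 nM. Compound 3 `ClCc1ccc(Cn2cnc3c(Cl)nc(Cl)nc32)cc1` differs from compound 1 in one place, (chloro in place of hydrogen on an aromatic carbon); in this assay compound 3 gives 33100 nM, and that step is a 1.1-fold higher number from compound 1 to compound 3 (0.06 log units; within the scatter). Compound 2 `ClCc1ccccc1Cn1cnc2ncnc(Cl)c21` is built from the same atoms as compound 1, joined differently; the difference between the two cores is not broken down here. In this assay compound 2 gives 21900 nM, and the three values lie within the scatter of one another.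

Compound 4 `ClCc1ccccc1Cn1cnc2nc(Cl)nc(Cl)c21` awaits measurement. It differs from compound 2 by chloro in place of hydrogen on an aromatic carbon, the same change that turns compound 1 into compound 3. A step of similar size is expected, a 1.1-fold higher number from compound 2 to compound 4 (0.04 log units; within the scatter), because the earlier one was a 1.1-fold higher number from compound 1 to compound 3 (0.06 log units; within the scatter). Compound 4 is thus estimated at 24000 nM, with a likely span from 12000 nM to 48000 nM.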

Compound 4, concentration for total growth inhibition: 4160 nM
The estimate for compound 4 lay 5.8-fold (0.76 log units) above the measured number, and the stated range ends above it.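

In this assay, placing chloro on the aromatic carbon between two ring nitrogen atoms gives a 5.3-fold lower number from compound 2 to compound 4 (0.72 log units; beyond the scatter). This change does not carry over with the same size from one core to the other: the same change on two cores in this assay, a 1.1-fold higher number (0.06 log units; within the scatter) from compound 1 to compound 3 and a 5.3-fold lower number (0.72 log units; beyond the scatter) from compound 2 to compound 4, 6.1-fold (0.78 log units) apart, beyond the scatter of two such steps. The size of this step therefore depends on the core in these two pairs, but two pairs cannot show why the cores differ or predict what the change would do on a third core.

Among these compounds, it remains open whether an amine or a methoxy group on that same carbon would give a step like the one to compound 4. On these data alone, it is equally open whether a bromo group there would behave as chloro does on each core.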